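The compounds below may be only part of what the source reports. "The series", "measured", "known", "first", "only" and "open" are said of these compounds alone.

Measured so far: compound 1 `O=C(O)c1ccccc1-c1ccc(CCc2ncc(Cc3ccccc3F)[nH]2)cc1` at 177 nM; compound 2 `Cc1cccc(Cc2cnc(CCc3ccc(-c4ccccc4C(=O)O)cc3)[nH]2)c1` at 4310 nM.

In an in vitro functional assay on cells for agonist activity at Bombesin receptor subtype-3 (Homo sapiens), read by luminescence and calcium flux (on this read-out lower numbers stand for an effect already at smaller amounts and higher numbers for an effect only at larger amounts of compound), compound 2 stands with the highest of the two numbers shown, its nearest neighbour being compound 1, and the step of a 24-fold higher number from compound 1 to compound 2 (1.39 log units; beyond the scatter) lies beyond the scatter. Compound 3 `O=C(O)c1ccccc1-c1ccc(CCc2ncc(Cc3cccc(Cl)c3)[nH]2)cc1` differs from compound 2 by chloro in place of methyl on an aromatic carbon. Among the measured compounds shown here, no measured step tests this exchange directly; the single step, a 24-fold higher number from compound 1 to compound 2 (1.39 log units; beyond the scatter), swaps 2-fluorophenyl for 3-methylphenyl and so bears only loosely. A shift of modest size toward a lower number is therefore expected, a 2.0-fold lower number from compound 2 to compound 3 (0.29 log units; within the scatter). Compound 3 is estimated at 2200 nM, with a range from 500 nM to 9000 nM.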

Compound 3, half-maximal effective concentration: 825 nM
Compound 3: middle estimate off by 2.7-fold (0.43 log units), on the high side, and the stated range covers the measured number.
By their numbers in this assay, from the lowest: compound 1; then compound 3; then compound 2.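

Replacing 3-methylbenzyl with 3-chlorobenzyl in this assay gives a 5.2-fold lower number from compound 2 to compound 3 (0.72 log units; beyond the scatter) with the place held fixed, so the group on this aromatic carbon alone moves the number, which the earlier step, changing group and place together, could not show. The 3-chlorophenyl group still does not match 2-fluorophenyl (a 4.7-fold higher number from compound 1 to compound 3 (0.67 log units; beyond the scatter)), so part of the earlier gap remains. Nothing available accounts for either step.

Still open, from the compounds shown here alone, is whether the atom or its place carries the remaining gap, and how a methoxy group or an amine on this ring would read.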